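The compounds below may be only part of what the source reports. "The series", "measured", "known", "first", "only" and "open" are said of these compounds alone.

Values in a physicochemical assay for solubility, in phosphate buffer, with a stated time of 18 h, at pH 7.4; on this read-out higher numbers stand for higher solubility and lower numbers for lower solubility:
- compound 1 `COc1cc2ncnc(-n3nc(-c4ccccn4)nc3N)c2cc1N`: 3000 nM
- compound 2 `COCCOc1cc2ncnc(-n3nc(-c4ccccn4)nc3N)c2cc1OCCOC`: 30000 nM
- compound 3 `COCCOc1cc2c(-n3nc(-c4ccccn4)nc3N)ncnc2cc1OC`: 8000 nM

Compound 3 is the second highest of the three numbers in this assay, and the next compound to consider is compound 4 `COc1cc2ncnc(-n3nc(-c4ccccn4)nc3N)c2cc1OCCCNC(=O)OCC(F)(F)F`. The change from compound 3 is (((2,2,2-trifluoroethoxy)carbonyl)amino)methyl in place of methoxy on a saturated chain carbon, two bonds along the chain from an oxygen on an aromatic ring. In words, it is (((2,2,2-trifluoroethoxy)carbonyl)amino)methyl in place of methoxy on a saturated chain carbon, two bonds along the chain from an oxygen on an aromatic ring.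

The closest measured step is a 3.8-fold lower number from compound 2 to compound 3 (0.57 log units; beyond the scatter), with hydrogen in place of methoxymethyl on a saturated chain carbon bound to an oxygen on an aromatic ring. The other is a 2.7-fold higher number from compound 1 to compound 3 (0.43 log units; beyond the scatter), with 2-methoxyethoxy in place of amino on an aromatic carbon. Among the measured compounds shown here, both are modest, and no measured compound carries the entering group, so the direction is a tentative judgement. A modest fall in this assay is expected, in size like those two steps.

The estimated step is a 3.2-fold lower number from compound 3 to compound 4 (0.51 log units; beyond the scatter).

For compound 4 the expected value is 2500 nM, with an estimated range from 600 nM to 10000 nM.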

Compound 4, solubility: 100 nM
Estimate against measurement, compound 4: 25-fold (1.40 log units) above; measured number outside the range, below it.
By their numbers in this assay, from the lowest: compound 4; then compound 1; then compound 3; then compound 2.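

In this assay, (((2,2,2-trifluoroethoxy)carbonyl)amino)methyl in place of methoxy, on a saturated chain carbon, two bonds along the chain from an oxygen on an aromatic ring, gives an 80-fold lower number from compound 3 to compound 4 (1.90 log units; beyond the scatter), a large step. Among the compounds shown here, the earlier steps were both modest, a 3.8-fold lower number from compound 2 to compound 3 (0.57 log units; beyond the scatter) and a 2.7-fold higher number from compound 1 to compound 3 (0.43 log units; beyond the scatter), so this large step is the first sign that a change on this chain can move the number this far. Nothing available bears on why the fall is this large.

Open, going by these compounds, is which part of the 3-(((2,2,2-trifluoroethoxy)carbonyl)amino)propyl group goes with the fall. A free amine or a carboxylic acid at the end of that chain would help to separate the effect of the chain from that of its terminal group.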